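The source may report more compounds than this note shows. Statements on the series, on what has been measured and on what is new or still open speak of the compounds shown alone.

Measured so far in a functional assay on MCF7 cells (Homo sapiens) for antiproliferative activity, read by MTT assay, with a stated time of 24 h, tested at 12.5 uM; a lower number here means a stronger effect, a higher number a weaker effect of the compound at the concentration tested:
compound 1 `COc1cccc(C(O)CCn2nc3c(Br)c(Br)c(Br)c(Br)c3n2)c1` — 121%
compound 2 `OC(CCn1nc2c(Br)c(Br)c(Br)c(Br)c2n1)c1ccccc1` — 115%
compound 3 `OC(CCn1nc2c(Br)c(Br)c(Br)c(Br)c2n1)c1ccc(Br)cc1` — 82%

Compound 3 holds the lowest of the three numbers in this assay; its nearest neighbour is compound 2, and both gaps, to compound 2 and to compound 1, lie beyond the scatter. Compounds 1 and 2 sit within the scatter of each other, so no order is read between them.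

Compound 4 `CC(O)CCn1nc2c(Br)c(Br)c(Br)c(Br)c2n1` is not yet measured. It differs from compound 3 by methyl in place of 4-bromophenyl on a saturated chain carbon bound to an oxygen on a saturated carbon and a saturated chain carbon.

For the measured compounds named here, two measured steps bear on this place. a number 33 percentage points lower from compound 2 to compound 3 (beyond the scatter) ties the low number of compound 3 to the bromo on the aromatic carbon. a number 39 percentage points lower from compound 1 to compound 3 (beyond the scatter) points the same way. Going by the values given here, no measured step removes the aromatic ring itself, so the weight of the ring alone is unknown. With the bromo gone as well, the effect seen in a number 33 percentage points lower from compound 2 to compound 3 (beyond the scatter) is expected to reverse, giving an expected step of a number 26 percentage points higher from compound 3 to compound 4 (beyond the scatter). For compound 4 the estimate in this assay is 108%, expected between 88% and 128%.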

Compound 4, a percentage reported as activity, at one concentration (the size of the read-out at that concentration, not a potency): 99%
For compound 4 the middle estimate is 9 percentage points above the measured one, within the range that was stated.
By their numbers in this assay, from the lowest: compound 3; then compound 4; then compounds 2 and 1 (each within the scatter of the next).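

In this assay, methyl in place of the aromatic group does not act in one direction at this position: the change gives a number 17 percentage points higher from compound 3 to compound 4 (beyond the scatter) where 4-bromophenyl leaves, but a number 16 percentage points lower from compound 2 to compound 4 (beyond the scatter) where phenyl leaves and a number 22 percentage points lower from compound 1 to compound 4 (beyond the scatter) where 3-methoxyphenyl leaves. Methyl, with no ring, therefore stands between 4-bromophenyl and the two groups without bromine, so an aromatic ring on this carbon does not by itself go with the lower number. Of the groups shown, only 4-bromophenyl gives a lower number than methyl, while phenyl and 3-methoxyphenyl go against any reading that a larger group gives a lower number.

Going by these compounds, whether a longer alkyl chain, a 4-chlorophenyl group or an amine on this carbon would side with methyl or with 4-bromophenyl stays open. Nothing in the data shown explains these differences.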